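The source may report more compounds than this note shows. Statements on the series, on what has been measured and on what is new or still open speak of the compounds shown alone.

Of the compounds shown here, two have been tested in a toxicity assay on the whole organism with Rattus norvegicus as the target, at a dose of 100 mg/kg by the oral route; a lower number here means a weaker effect, a higher number a stronger effect of the compound at the dose given. Compound 1 `Brc1ccccc1OCC1=NCCO1` gives 10% in this assay. Compound 2 `Cc1cc(OCC2=NCCO2)ccc1Cl` gives 20% in this assay, a number within the scatter of that of compound 1, so the two stand together at the weak end of what is known. Compound 3 `O=[N+]([O-])c1ccccc1OCC1=NCCO1` is not yet measured; it differs from compound 1 by nitro in place of bromo on an aromatic carbon. For the measured compounds named here, no measured pair shows what such a change does here, so the step of a number 5 percentage points higher from compound 1 to compound 3 (within the scatter) is expected to stay within the scatter. In this assay compound 3 is expected to give about 15%, between 0% and 35%.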

Compound 3, a percentage reported as activity, at one dose (the size of the read-out at that dose, not a potency): 20%
For compound 3 the middle estimate is 5 percentage points below the measured one, within the range that was stated.
By their numbers in this assay, from the lowest: compounds 1, 2 and 3 (each within the scatter of the next).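

In this assay, for the compounds shown here, nitro in place of bromo on an aromatic carbon gives a number 10 percentage points higher from compound 1 to compound 3 (within the scatter) as the only one-place step so far. This position, ortho to a group of 7 heavy atoms, therefore accepts this exchange, with 3 heavy atoms entering for 1 and 2 hydrogen-bond acceptors gained, without a change beyond the scatter. No available data account for this result.

As far as these compounds go, whether an amine or a carboxylic acid at this position would move the read-out beyond the scatter stays open. Also open, from the compounds shown here alone, is what a longer chain in place of the group of 7 heavy atoms would do.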